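The source may hold more compounds than are shown below. What is called first, only, known or untested is meant among the compounds shown, and "the series" means these compounds.

Compound 3 `CCNC(=O)C1=C(C)NC(=O)NC1c1cccs1` gives 1% in an assay on membranes from HEK293 cells for displacement of a labelled ligand from adenosine receptor A2b (Homo sapiens), read by scintillation counting, with a stated time of 30 min, tested at 1 uM (a higher number here means more inhibition at the concentration tested (going by the name of the read-out), a lower number less inhibition), the lowest of the three numbers, though only its distance from compound 2 `CC1=C(C(=O)CC(C)C)C(c2cccs2)NC(=O)N1`, which gives 43%, lies beyond the scatter; compound 1 `CCCC(=O)C1=C(C)NC(=O)NC1c1cccs1` gives 9%, within the scatter of compound 3. Compound 4 `CC1=C(C(=O)NC(C)C)C(c2cccs2)NC(=O)N1` differs from compound 3 by methyl in place of hydrogen on a saturated chain carbon bound to an amide-type nitrogen and a saturated chain carbon. Within the data shown here, the one measured step that resembles this, methyl in place of hydrogen on a saturated chain carbon, is a number 34 percentage points higher from compound 1 to compound 2 (beyond the scatter), a large gain; the step of a number 42 percentage points lower from compound 2 to compound 3 (beyond the scatter) shows how much that branched chain mattered. On that basis a rise is expected, though a single precedent is thin support. Compound 4 is therefore estimated at 20%, between 0% and 45%, an expected step of a number 19 percentage points higher from compound 3 to compound 4 (beyond the scatter).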

Compound 4, a percentage reported as inhibition, at one concentration (the size of the read-out at that concentration, not a potency): 40%
For compound 4 the middle estimate is 20 percentage points below the measured one, within the range that was stated.
By their numbers in this assay, from the lowest: compounds 3 and 1 (each within the scatter of the next); then compounds 4 and 2 (each within the scatter of the next).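

In this assay, the methyl that turns ethylamino into isopropylamino gives a number 39 percentage points higher from compound 3 to compound 4 (beyond the scatter), and the isopropylamino group then stands level with isobutyl, a number 3 percentage points lower from compound 2 to compound 4 (within the scatter), and clear of propyl, a number 31 percentage points higher from compound 1 to compound 4 (beyond the scatter). Among these compounds, the branched chains give the higher numbers, whether the carbonyl carbon carries a nitrogen or a carbon. The gain from this methyl therefore does not belong to one chain, and it recurs at a similar size: the same change on two cores in this assay, a number 34 percentage points higher (beyond the scatter) from compound 1 to compound 2 and a number 39 percentage points higher (beyond the scatter) from compound 3 to compound 4, 5 percentage points apart, within the scatter of two such steps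

As far as these compounds go, whether a larger branch, such as tert-butylamino, raises the number further stays open. So does the effect of a cyclopentylamino group or of a carboxylic acid at the chain end.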